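A Benzyl Ring Swap in a Weakly Active Series

This account rests on a few compounds, and the source may have more. Where it says the series, first, only, none or still open, it means among the compounds named here.

compound 1, `Cc1ccsc1/C=C(/SCc1ccc(Cl)cc1)C(=O)c1ccc(Cl)cc1`: 50000 nM in a functional assay on DU-145 cells (Homo sapiens) for inhibition, read by trypan blue exclusion, with a stated time of 96 h; a lower number here means a stronger inhibitor of growth, a higher number a weaker inhibitor of growth
compound 2, `Cc1ccc(/C=C(/SCc2ccc(Cl)cc2)C(=O)c2ccc(Cl)cc2)s1`: 50000 nM
compound 3, `Cc1ccsc1/C=C(/SCc1ccc(Cl)cc1)C(=O)c1ccc([N+](=O)[O-])cc1`: > 100000 nM, which is a limit of the assay and not a number

Compound 1 stands level with compound 2 at the digits shown; the step of no change at the digits printed from compound 1 to compound 2 (within the scatter), a 5-methylthiophen-2-yl in place of a 3-methylthiophen-2-yl, lies within the scatter. Compound 3 sits at the limit of > 100000 nM in this assay, at which 1 of the 3 values shown sits. The step of an at least 2.0-fold higher number from compound 1 to compound 3 (0.30 log units; that floor lies within the scatter) therefore has only a floor, and that floor lies within the scatter as well.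

Compound 4, `Cc1ccsc1/C=C(/SCc1ccccc1F)C(=O)c1ccc(Cl)cc1`, differs from compound 1 by 2-fluorophenyl in place of 4-chlorophenyl on a saturated chain carbon bound to a sulfur. Neither measured step bears directly on this change: one alters the methylthiophenyl group, the other exchanges chloro for nitro on an aromatic carbon, and both leave the 4-chlorobenzyl untouched. The two steps that are known were both within the scatter, so the series gives no sign of movement in either direction, and the estimate for compound 4 is a step of no change at the digits printed from compound 1 to compound 4 (within the scatter) that is expected to stay within the scatter. Compound 4 is therefore expected to give about 50000 nM, with a range from 20000 nM to 100000 nM.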

Compound 4, concentration for 50% growth inhibition: 50000 nM
Estimate against measurement, compound 4: no gap at the digits printed; measured number inside the range.
By their numbers in this assay, from the lowest: compounds 1, 2 and 4 (each within the scatter of the next). At a limit, above all of these: compound 3.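

In this assay, among these compounds, the earlier compounds changed the methylthiophenyl group and the chloro on the aromatic ring of the ketone, and all of them kept the 4-chlorobenzyl, so this is the first look at the group on the saturated chain carbon bound to a sulfur. The step, no change at the digits printed from compound 1 to compound 4 (within the scatter), shows that 2-fluorophenyl can stand in place of 4-chlorophenyl at this position with no reading outside the scatter, which extends the flat picture from the methylthiophenyl change to this second part of the molecule. This one step, however, exchanges the halogen and its ring position together, so it cannot say what either exchange does alone, and nothing measured here accounts for the unchanged number.

Going by these compounds, what stays open is whether any group at this position moves the number at all, for instance a 4-aminobenzyl, a 4-methoxybenzyl or a longer chain such as 2-phenylethyl. Equally open, on these data alone, is whether a carboxylic acid on this benzyl ring would give a reading beyond the scatter in this assay.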